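This account rests on a few compounds, and the source may have more. Where it says the series, first, only, none or still open, it means among the compounds named here.

Compound 1, `COc1cccc(-c2ccc(C(=O)N3CCN(C(=O)c4ccc5cc[nH]c5c4)C[C@@H]3C)cc2)c1`, gives 280 nM in a functional assay on CHO-K1 cells for antagonist activity at growth hormone secretagogue receptor type 1 (Homo sapiens), read by luminescence and calcium flux; on this read-out higher numbers stand for weaker inhibition and lower numbers for stronger inhibition.
Compound 2, `O=C(c1ccc(-c2ccccc2)cc1)N1CCCN(C(=O)c2ccc3cc[nH]c3c2)CC1`, gives 6500 nM.
Compound 3, `C[C@H]1CN(C(=O)c2ccc(-c3ccccc3)cc2F)CCN1C(=O)c1ccc2cc[nH]c2c1`, gives 17.7 nM.

Of the three measured compounds, compound 3 stands at the lowest number in this assay, which on this read-out means the strongest inhibition. Compound 1 is its nearest neighbour, and the gap between them lies beyond the scatter of repeated measurements. Compound 2 lies furthest away, at a gap that is larger still. Among the compounds with values here, neither of these pairs differs from compound 3 in a single place, so the two values of each pair show only that compound 3 sits well apart from both.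

Compound 4, `Cc1cc(-c2ccccc2)ccc1C(=O)N1CCN(C(=O)c2ccc3cc[nH]c3c2)[C@@H](C)C1`, has not yet been measured. It differs from compound 3 by methyl in place of fluoro on an aromatic carbon, ortho to a large group and meta to a phenyl group. Within the data shown here, no measured pair isolates this exchange, so the expected step rests on the two groups being of the same count of heavy atoms. A small step toward weaker inhibition, near the edge of the scatter, is expected. Compound 4 is therefore estimated at 35 nM, with a range from 9 nM to 140 nM. That estimate means an expected step of a 2.0-fold higher number from compound 3 to compound 4 (0.30 log units; within the scatter).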

Compound 4, half-maximal inhibitory concentration: 14.3 nM
For compound 4 the middle estimate is 2.4-fold (0.39 log units) above the measured one; low and high end bracket the measured number.
By their numbers in this assay, from the lowest: compounds 4 and 3 (each within the scatter of the next); then compound 1; then compound 2.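

In this assay, placing methyl in place of fluoro on an aromatic carbon, ortho to a large group and meta to a phenyl group, gives a 1.2-fold lower number from compound 3 to compound 4 (0.09 log units; within the scatter) and so leaves the read-out unchanged within the usual scatter of repeated measurements. Within the data shown here, this is the first pair that differs in one place, so it gives the first direct reading of any single position. Compounds 1, 2 and 3 differ from one another in more than one place, and they could not provide such a reading. At this position, on this read-out, the two groups cannot be told apart, and compound 3 and compound 4 stand together as a pair, though this single exchange says nothing about the rest of the molecule. Nothing in the data presented explains why the two groups read alike.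

The compounds shown leave open how this position would read with no substituent at all, or with a chlorine, a trifluoromethyl group, an amine or a carboxylic acid. They also leave open whether a larger group here would stay as close to compound 3 as methyl does, and whether the same exchange would read alike on another core.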